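Phenyl to Benzyl on the Quinoline-Type Core

The compounds below may be only part of what the source reports. "The series", "measured", "known", "first", "only" and "open" are said of these compounds alone.

Compound 3 `Fc1ccc(-c2ccc3c(NCCCNCc4ccco4)ccnc3c2)cc1` gives 32000 nM in a physicochemical assay for solubility, with a stated time of 18 h, at pH 7.4; on this read-out higher numbers stand for higher solubility and lower numbers for lower solubility. It stands level with compound 2 `c1ccc(-c2ccc3c(NCCCNCc4ccco4)ccnc3c2)cc1`, which gives 32000 nM; together they hold the highest of the three numbers, while compound 1 `CC(C)Cc1ccc2c(NCCCNCc3ccco3)ccnc2c1` gives 4200 nM. The steps of a 7.6-fold higher number from compound 1 to compound 2 (0.88 log units; beyond the scatter) and a 7.6-fold higher number from compound 1 to compound 3 (0.88 log units; beyond the scatter) show that a phenyl or 4-fluorophenyl on the aromatic carbon gave a higher number than isobutyl, and no change at the digits printed from compound 2 to compound 3 (within the scatter) shows no change beyond the scatter. Compound 4 `Fc1ccc(Cc2ccc3c(NCCCNCc4ccco4)ccnc3c2)c(Cl)c1` differs from compound 3 by 2-chloro-4-fluorobenzyl in place of 4-fluorophenyl on an aromatic carbon. Among the compounds with values here, no measured step covers a benzyl or a chloro. The change is expected to give a 1.8-fold lower number from compound 3 to compound 4 (0.25 log units; within the scatter) in this assay, a small downward step that may stay within the scatter. Compound 4 is therefore estimated at 18000 nM in this assay, between 6000 nM and 40000 nM.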

Compound 4, solubility: 4200 nM
Compound 4: middle estimate off by 4.3-fold (0.63 log units), on the high side; measured number below the stated range.
By their numbers in this assay, from the lowest: compounds 1 and 4 (each within the scatter of the next); then compounds 2 and 3 (each within the scatter of the next).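

With the 2-chloro-4-fluorobenzyl group at this position, this assay shows a 7.6-fold lower number from compound 3 to compound 4 (0.88 log units; beyond the scatter) and a 7.6-fold lower number from compound 2 to compound 4 (0.88 log units; beyond the scatter), so this change moves the number where the earlier fluoro step did not. Against isobutyl it shows no change at the digits printed from compound 1 to compound 4 (within the scatter), so in these four compounds the two groups joined through a saturated carbon sit low and the two joined directly through an aromatic ring sit high. Nothing measured here gives a reason for these steps. The compounds shown leave open whether an unsubstituted benzyl would stand with the low pair or the high pair, and whether a 2-chlorophenyl would stay with the high pair.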